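The compounds below may be only part of what the source reports. "The series", "measured", "known", "first", "only" and "open" are said of these compounds alone.

Measured in a functional assay on MCF7 cells (Homo sapiens) for antiproliferative activity; a lower number here means a stronger inhibitor, a higher number a weaker inhibitor:
compound 1 `O=c1oc2cc(O)ccc2c(Cc2ccc(OCCCN3CCCCC3)cc2)c1-c1ccccc1`: 18 nM
compound 2 `O=c1oc2cc(O)ccc2c(-c2ccc(OCCCCN3CCCCC3)cc2)c1-c1ccccc1`: 134 nM
compound 3 `O=c1oc2cc(O)ccc2c(-c2cccc(OCCCN3CCCCC3)c2)c1-c1ccccc1`: 9.5 nM

Compound 2, at 134 nM, has the highest number of the three, and its gaps to the other two lie beyond the scatter. The next structure is compound 4 `O=c1oc2cc(O)ccc2c(-c2ccc(OCCCN3CCCCC3)cc2)c1-c1ccccc1`: piperidin-1-yl in place of (piperidin-1-yl)methyl on a saturated chain carbon, three bonds along the chain from an oxygen on an aromatic ring. Read one bond further out, this is 4-(piperidin-1-yl)butyl to 3-(piperidin-1-yl)propyl.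

Among the measured compounds shown here, no measured pair isolates this change. The 3-(piperidin-1-yl)propyl group is present in compound 1 at 18 nM and in compound 3 at 9.5 nM, though both also differ from compound 4 elsewhere. The expected step of a 6.7-fold lower number from compound 2 to compound 4 (0.83 log units; beyond the scatter) runs to a lower number in this assay, beyond the scatter. Compound 4 is estimated at 20 nM, with an expected range of 6 nM to 70 nM.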

Compound 4, half-maximal inhibitory concentration: 335 nM
For compound 4 the middle estimate is 17-fold (1.22 log units) below the measured one; the whole stated range lies below it.
By their numbers in this assay, from the lowest: compounds 3 and 1 (each within the scatter of the next); then compound 2; then compound 4.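

In this assay, shortening 4-(piperidin-1-yl)butyl to 3-(piperidin-1-yl)propyl on the para-free chain gives a 2.5-fold higher number from compound 2 to compound 4 (0.40 log units; beyond the scatter) (the longer chain carries the lower number at this position).

Correction of the working note follows.

In this assay, the change from 4-(piperidin-1-yl)butyl to 3-(piperidin-1-yl)propyl gives a 2.5-fold higher number from compound 2 to compound 4 (0.40 log units; beyond the scatter), so at this position the shorter chain carries the higher number. The 3-(piperidin-1-yl)propyl group therefore does not bring a low number on its own in this compound. No available evidence explains this step.

On these data alone, whether a 5-(piperidin-1-yl)pentyl or 2-(piperidin-1-yl)ethyl chain would continue this direction remains open. So does whether a pyrrolidine or dimethylamino group in place of piperidine would behave the same way.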